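From piperidin-1-yl to 4-methylpiperidin-1-yl

A few compounds are considered here, and "the series" means these few. Any claim that something is new, unique, unknown or untested is made for them only; others in the source may bear on it.

In a functional assay on A549 cells (Homo sapiens) for cytotoxicity, read by WST assay, with a stated time of 72 h (on this read-out lower numbers stand for stronger inhibition and higher numbers for weaker inhibition), compound 1 `COc1cc2c(Nc3nc4ccc(C(=O)Nc5c(C)cccc5C)cc4s3)ncnc2cc1OCCCN1CCCC1` gives 83800 nM. Compound 2 `CCN(CC)CCCOc1cc2ncnc(Nc3nc4ccc(C(=O)Nc5c(C)cccc5C)cc4s3)c2cc1OC` gives > 100000 nM, which is a limit of the assay and not a number. Compound 3 `COc1cc2c(Nc3nc4ccc(C(=O)Nc5c(C)cccc5C)cc4s3)ncnc2cc1OCCCN1CCCCC1` gives > 100000 nM, again only a limit. Going by these compounds, compound 3 therefore stands at the limit of > 100000 nM in this assay, at which 2 of the 3 values shown sit, so its true value is unknown.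

Compound 4 `COc1cc2c(Nc3nc4ccc(C(=O)Nc5c(C)cccc5C)cc4s3)ncnc2cc1OCCCN1CCC(C)CC1` differs from compound 3 by a single small change: methyl in place of hydrogen on a saturated ring carbon. In words, this is methyl in place of hydrogen on a saturated ring carbon, far out on the chain.

The measured steps that bear on this change all swap the group at the end of that chain. There is an at least 1.1-fold higher number from compound 1 to compound 3 (0.07 log units; that floor lies within the scatter), and there is an at least 1.1-fold higher number from compound 1 to compound 2 (0.07 log units; that floor lies within the scatter). The third is a step that the two limits leave unreadable from compound 2 to compound 3. Going by the values given here, neither readable floor goes beyond the scatter, and no measured step shows what a methyl does here. With an at least 1.1-fold higher number from compound 1 to compound 3 (0.07 log units; that floor lies within the scatter) as the closest guide, no change beyond the scatter is expected in this assay, in either direction, and a further limit is the likeliest report.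

The estimated change is a number no higher from compound 3 to compound 4 (the limit leaves the size open). For compound 4 the expected value is 100000 nM, with an estimated range from 50000 nM to 200000 nM.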

Compound 4, half-maximal inhibitory concentration: 89700 nM
Beside the measured number, compound 4's estimate is 1.1-fold (0.05 log units) above it, within the range that was stated.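

In this assay, compound 4 gives a measured number, so a six-membered end ring with a methyl on the saturated ring carbon, three ring bonds from the ring nitrogen, can be read as a value and not only as a limit. Going by these compounds alone, there is an at least 1.1-fold lower number from compound 3 to compound 4 (0.04 log units; that floor lies within the scatter), and there is an at least 1.1-fold lower number from compound 2 to compound 4 (0.04 log units; that floor lies within the scatter), and neither of these floors shows a real change, with the start of each step held only as a limit: the limit of > 100000 nM in this assay, at which 2 of the 4 values shown sit. The one step between two real numbers is a 1.1-fold higher number from compound 1 to compound 4 (0.03 log units; within the scatter), so in this assay a 4-methylpiperidin-1-yl group and a pyrrolidin-1-yl group at the end of the chain cannot be told apart.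

Going by these compounds, the true gap between compound 3 and compound 4 stays open, so it is still unknown whether the methyl does anything at all at this position. Also open, on these data alone, is whether a hydroxyl or a carboxylic acid on that same ring carbon, or a morpholin-4-yl group or a longer chain at the end of the side chain, would give a value clearly beyond the scatter.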